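Permeability notes: phenyl for pyridinylmethyl on the bicyclic core

The source may hold more compounds than are shown below. What is called first, only, known or untested is meant among the compounds shown, and "the series" means these compounds.

Measured so far:
Compound 1, `O=C(NCc1cc(Cl)ccc1-n1cnnn1)[C@@H]1C[C@@H]2C[C@@H]2N1C(=O)[C@H](O)Cc1ccccn1`: 1.2 10^-6 cm/s
Compound 2, `O=C(NCc1cc(Cl)ccc1-n1cnnn1)[C@@H]1CC=NN1C(=O)[C@H](O)c1ccccc1F`: 8.9 10^-6 cm/s
Compound 3, `O=C(NCc1cc(Cl)ccc1-n1cnnn1)[C@@H]1CCNN1C(=O)[C@H](O)c1ccccc1`: 5.3 10^-6 cm/s

All three were run in an ADME assay on Caco-2 cells (Homo sapiens) for permeability, read by LC-MS, in the apical to basolateral direction, with a stated time of 60 min, at pH 6.5; a lower number here means that the compound crosses the layer more slowly, a higher number that the compound crosses the layer faster. Compound 1 stands lowest of the three numbers. The nearest is compound 3, whose number is higher by more than the usual scatter; compound 2 lies furthest, also beyond the scatter. No two of the measured compounds differ in only one place, so neither gap can be tied to a single change.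

Compound 4, `O=C(NCc1cc(Cl)ccc1-n1cnnn1)[C@@H]1C[C@@H]2C[C@@H]2N1C(=O)[C@H](O)c1ccccc1`, keeps the core of compound 1 and differs from it in one place: phenyl in place of (pyridin-2-yl)methyl on a saturated chain carbon bound to a carbonyl carbon and an oxygen on a saturated carbon. Going by the values given here, no step between measured compounds covers this exact change. Among the compounds with values here, the only guide is compound 3, which carries phenyl at the same place on a different core and gives 5.3 10^-6 cm/s, well above compound 1. The expectation is therefore an upward step beyond the scatter, though the change of core between compound 1 and compound 3 leaves the size uncertain. The estimated step is a 3.8-fold higher number from compound 1 to compound 4 (0.57 log units; beyond the scatter). Compound 4 is expected to give 4.5 10^-6 cm/s in this assay, with a likely range from 2 10^-6 cm/s to 10 10^-6 cm/s.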

Compound 4, apparent permeability: 8 10^-6 cm/s
Beside the measured number, compound 4's estimate is 1.8-fold (0.25 log units) below it; the range from low to high includes it.
By their numbers in this assay, from the lowest: compound 1; then compounds 3, 4 and 2 (each within the scatter of the next).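

In this assay, phenyl in place of (pyridin-2-yl)methyl on the core of compound 1 gives a 6.7-fold higher number from compound 1 to compound 4 (0.82 log units; beyond the scatter), the only step shown that ties a gap in this series to one change. The position, on a saturated chain carbon bound to a carbonyl carbon and an oxygen on a saturated carbon, therefore responds to the group it carries, but the change replaces a group with 7 heavy atoms and 1 hydrogen-bond acceptor by one with 6 heavy atoms and 0 hydrogen-bond acceptors, so the step cannot be divided between the loss of the ring nitrogen and the shortening of the link to the ring. No measurement shown gives a reason for the step.

Benzyl or pyridin-2-yl at this position would separate the ring nitrogen from the link, and their values in this assay remain open. Also open, going by these compounds, is whether the same change gives a step of similar size on the other cores, and how an amine or a carboxylic acid on the phenyl would read.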